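The source may report more compounds than this note shows. Statements on the series, on what has been measured and on what is new or still open speak of the compounds shown alone.

Three compounds share one core and differ only in the group attached to the aromatic nitrogen. In an assay on isolated protein for inhibition of methionine--tRNA ligase, cytoplasmic (Homo sapiens) (a higher number here means a weaker inhibitor, a lower number a stronger inhibitor), compound 1 `O=C(O)c1cc(-c2ccc(-c3ccc(Cl)cc3Cl)cc2)n(-c2ccc(Cl)cc2Cl)n1` gives 11900 nM, compound 2 `O=C(O)c1cc(-c2ccc(-c3ccc(Cl)cc3Cl)cc2)n(Cc2ccncc2)n1` gives 26200 nM, and compound 3 `O=C(O)Cn1nc(C(=O)O)cc1-c1ccc(-c2ccc(Cl)cc2Cl)cc1` gives 100000 nM, the highest of the three numbers; the steps of an 8.4-fold higher number from compound 1 to compound 3 (0.92 log units; beyond the scatter) and a 3.8-fold higher number from compound 2 to compound 3 (0.58 log units; beyond the scatter) both lie beyond the scatter. Compound 4 `O=C(O)c1cc(-c2ccc(-c3ccc(Cl)cc3Cl)cc2)n(CCO)n1` carries the change (hydroxymethyl in place of carboxy on a saturated chain carbon bound to an aromatic nitrogen). The step that bears most directly on it is a 3.8-fold higher number from compound 2 to compound 3 (0.58 log units; beyond the scatter), showing that swapping the group on that chain carbon shifts the number in this assay by a modest amount. A modest fall in the number is therefore expected, a 2.0-fold lower number from compound 3 to compound 4 (0.30 log units; within the scatter). Compound 4 is estimated at 50000 nM, with a range from 20000 nM to 120000 nM.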

Compound 4, half-maximal inhibitory concentration: > 100000 nM
Compound 4: no number, only a limit; the forecaster's own chance of this, stated with the estimate: 30%; middle value at least 2.0-fold (0.30 log units) away from the limit.
By their numbers in this assay, from the lowest: compound 1; then compound 2; then compound 3.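

In this assay compound 4 gives > 100000 nM, a limit of the assay and not a number. Moving to the 2-hydroxyethyl chain loses ground against both groups that carry a ring, with an at least 3.8-fold higher number from compound 2 to compound 4 (0.58 log units; beyond the scatter) and an at least 8.4-fold higher number from compound 1 to compound 4 (0.92 log units; beyond the scatter). Exchanging carboxymethyl for 2-hydroxyethyl brings a number no lower from compound 3 to compound 4 (the limit leaves the size open), and the size of that step cannot be read: the limit of > 100000 nM in this assay, at which 1 of the 4 values shown sits.

Still open, as far as these compounds go, is whether a 2-aminoethyl group or a longer chain on the aromatic nitrogen would bring the number down towards those of the ring-bearing compounds.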